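The compounds below may be only part of what the source reports. "The series", "measured", "known", "first", "only" and "open" are said of these compounds alone.

Compound 1 `CCCOc1ccc([C@@H]2CC(=O)c3cc(CC=C(C)C)c(OC)cc3O2)cc1` gives 63%
Compound 2 `COc1ccc([C@@H]2C/C(=N/OCc3cn(-c4cccc(CO)c4)nn3)c3cc(CC=C(C)C)c(OC)cc3O2)cc1` gives 27%
Compound 3 `COc1cc2c(cc1CC=C(C)C)/C(=N/NC(N)=O)C[C@@H](c1ccc(O)cc1)O2` gives 87%

These three compounds were tested in a functional assay on HCT-116 cells (Homo sapiens) for inhibition, read by sulforhodamine B assay, with a stated time of 48 h, tested at 50 uM (a lower number here means less inhibition of growth, a higher number more inhibition of growth at the concentration tested), and span a wide range of values. Compound 1 (63%) stands second highest of the three. Compound 3 (87%) lies above it and compound 2 (27%) lies below it, both gaps beyond the usual scatter.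

The next compound to be examined is compound 4 `CCOc1ccc([C@@H]2CC(=O)c3cc(CC=C(C)C)c(OC)cc3O2)cc1`, which has not yet been measured in this assay. It differs from compound 1 in one place only: hydrogen in place of methyl on a saturated chain carbon, two bonds along the chain from an oxygen on an aromatic ring. In plain terms, propoxy becomes ethoxy, and the rest of the structure stays the same.

Within the data shown here, no pair of measured compounds differs in a single place, so the data offer no direct precedent for this change. The gaps around compound 1 come from compounds that differ from it in more than one place, and they say little about so small an edit. The expectation in this assay is therefore no step beyond the scatter, in either direction. The estimate stays anchored on compound 1 (63%). The expected a number 3 percentage points lower from compound 1 to compound 4 (within the scatter) is accordingly small. For compound 4 the estimated value is 60%, with an expected range from 43% to 77%.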

Compound 4, percent growth inhibition at one concentration: 65%
Compound 4: middle estimate off by 5 percentage points, on the low side; measured number inside the range.
By their numbers in this assay, from the lowest: compound 2; then compounds 1 and 4 (each within the scatter of the next); then compound 3.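

In this assay, among these compounds, the change from propoxy to ethoxy gives a number 2 percentage points higher from compound 1 to compound 4 (within the scatter) and is the first comparison in this set that isolates a single place. Hydrogen in place of methyl on a saturated chain carbon, two bonds along the chain from an oxygen on an aromatic ring, therefore leaves compound 1 and compound 4 indistinguishable in this read-out at the one concentration tested, something the earlier compounds, none of which differed in only one place, could not show. The data offer no measurement that accounts for this outcome.

The compounds shown leave open whether this indifference extends beyond the propyl to ethyl edit, as only one step along this chain can be read, and a single step marks no trend. A longer chain such as butoxy, or an amine at the end of the chain, would test whether this position accepts larger changes in this assay as well as it accepts this one.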